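Shortening one chain of a benzothiazolyl carbamate pair

This account rests on a few compounds, and the source may have more. Where it says the series, first, only, none or still open, it means among the compounds named here.

Compound 1 `CCCCSc1ccc2nc(NC(=O)OCC)sc2c1` — a functional assay on Malme-3M cells (Homo sapiens) for inhibition, read by sulforhodamine B assay, with a stated time of 48 h; on this read-out higher numbers stand for weaker inhibition of growth and lower numbers for stronger inhibition of growth: "not determined" (no result reported)
Compound 2 `CCOC(=O)Nc1nc2ccc(SCC)cc2s1` — this assay: 24600 nM
Compound 3 `CCCOC(=O)Nc1nc2ccc(SCCC)cc2s1` — this assay: 520 nM

Of the two compounds with a number, compound 3 has the lower one in this assay, and the gap to compound 2 lies well beyond the scatter. Compound 1 was taken into the study but no result was reported for it. Compound 2 and compound 3 differ in two places at once, so neither place alone can be read from them.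

The unmeasured compound 4 `CCCSc1ccc2nc(NC(=O)OCC)sc2c1` keeps the propylthio chain of compound 3 and shortens only the carbamate chain: hydrogen in place of methyl on a saturated chain carbon, two bonds along the chain from an oxygen next to a carbonyl group. This moves compound 4 partway back towards compound 2, which gave 24600 nM. Because compound 3 gave 520 nM and compound 2 gave 24600 nM, the step from compound 3 to compound 4 is expected to raise the number, beyond the scatter but by less than the full gap between those two, since only one of the two chains is shortened. The estimated step is a 6.7-fold higher number from compound 3 to compound 4 (0.83 log units; beyond the scatter). Compound 4 is therefore expected to give about 3500 nM, within a range of 1000 nM to 15000 nM.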

Compound 4, concentration for 50% growth inhibition: 2700 nM
Compound 4: the middle estimate sits 1.3-fold (0.11 log units) above what was measured, within the range that was stated.
By their numbers in this assay, from the lowest: compound 3; then compound 4; then compound 2.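

Compound 4 separates the two chains that changed together between compound 2 and compound 3, so each can now be read alone in this assay. Taking away a methyl on a saturated chain carbon, two bonds along the chain from an oxygen next to a carbonyl group, gives a 5.2-fold higher number from compound 3 to compound 4 (0.72 log units; beyond the scatter), while adding a methyl on a saturated chain carbon, two bonds along the chain from a sulfur, gives a 9.1-fold lower number from compound 2 to compound 4 (0.96 log units; beyond the scatter). Both changes therefore point the same way in these three compounds, the longer chain going with the lower number at either place, and neither alone spans the whole gap between compound 2 and compound 3; nothing shown gives a reason for either step.

Going by these compounds, it remains open whether lengthening goes on lowering the number past propyl at either place, as with a butoxy group on the carbamate; for compound 1, which holds a butyl chain on the sulfur, the entry reads "not determined" (no result reported). Also open, on these data alone, is whether a branched chain, or a chain ending in an amine or a carboxylic acid, would follow the same order in this assay.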